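Amide substituent change on the shared core

A few compounds are considered here, and "the series" means these few. Any claim that something is new, unique, unknown or untested is made for them only; others in the source may bear on it.

Measured: compound 1 `Cc1ccc(CNC(=O)c2nn(-c3ccc(F)cc3)c(OC[C@@H](O)C[C@@H](O)CC(=O)O)c2C(C)C)cc1`, 2110 nM; compound 2 `COc1cccc(CN(C)C(=O)c2nn(-c3ccc(F)cc3)c(OC[C@@H](O)C[C@@H](O)CC(=O)O)c2C(C)C)c1`, 9460 nM.

Among the compounds with values here, in a functional assay on L6 cells (Rattus norvegicus) for inhibition (on this read-out lower numbers stand for stronger inhibition and higher numbers for weaker inhibition), compound 1 gives the lowest of the two numbers; the only other value, a 4.5-fold higher number from compound 1 to compound 2 (0.65 log units; beyond the scatter), stands beyond the scatter. Compound 3 `CC(C)c1c(C(=O)N(C)Cc2ccc(F)cc2)nn(-c2ccc(F)cc2)c1OC[C@@H](O)C[C@@H](O)CC(=O)O` differs from compound 1 by (4-fluorobenzyl)(methyl)amino in place of (4-methylbenzyl)amino on a carbonyl carbon. Within the data shown here, the one measured step bearing on this is that from compound 1 to compound 2, where (3-methoxybenzyl)(methyl)amino replaced the same (4-methylbenzyl)amino and the number rose modestly. A comparable weakening is expected for compound 3, a 2.8-fold higher number from compound 1 to compound 3 (0.45 log units; beyond the scatter). Compound 3 is estimated at 6000 nM, between 2500 nM and 15000 nM.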

Compound 3, half-maximal inhibitory concentration: 2800 nM
For compound 3 the middle estimate is 2.1-fold (0.33 log units) above the measured one; low and high end bracket the measured number.
By their numbers in this assay, from the lowest: compounds 1 and 3 (each within the scatter of the next); then compound 2.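

In this assay the change to (4-fluorobenzyl)(methyl)amino on the carbonyl carbon gives a 1.3-fold higher number from compound 1 to compound 3 (0.12 log units; within the scatter) and so stays within the scatter, which means that losing the amide hydrogen does not by itself weaken inhibition. Between the two methylated amides, 4-fluorophenyl in place of 3-methoxyphenyl gives a 3.4-fold lower number from compound 2 to compound 3 (0.53 log units; beyond the scatter), so the rise at compound 2 cannot be read as an effect of the amide methyl alone. No available measurement explains these differences. Still open, as far as these compounds go, is how (4-fluorobenzyl)amino without the methyl, or a phenethyl group on the amide nitrogen, would read on the shared core.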